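Swapping a side chain on a shared core

The source may report more compounds than this note shows. Statements on the series, on what has been measured and on what is new or still open speak of the compounds shown alone.

Measured so far in a functional assay on LNCaP cells (Homo sapiens) for antiproliferative activity, read by WST assay, with a stated time of 3 days; a lower number here means a stronger inhibitor, a higher number a weaker inhibitor
- compound 1 (`COc1cc(-c2oc3ccccc3c(=O)c2OC(C)C)cc(OC)c1OC`) gives 8800 nM
- compound 2 (`CCCC(C)Oc1c(-c2cc(OC)c(OC)c(OC)c2)oc2ccccc2c1=O`) gives 15100 nM

Compound 2 cannot be told apart from compound 1 on these numbers. Within the data shown here, the only measured step is a 1.7-fold higher number from compound 1 to compound 2 (0.23 log units; within the scatter) (ethyl in place of hydrogen on a saturated chain carbon). Compound 3 (`CCN(CC)CCCCCOc1c(-c2cc(OC)c(OC)c(OC)c2)oc2ccccc2c1=O`) differs from compound 2 much more: 5-(diethylamino)pentyl in place of 1-methylbutyl on an oxygen on an aromatic ring. Among the measured compounds shown here, the small measured edit is therefore only a weak guide, and no measured compound carries the entering group. The expected change in this assay is a modest drop, a tentative lean with wide uncertainty, and the estimated step is a 2.5-fold lower number from compound 2 to compound 3 (0.40 log units; beyond the scatter) (an estimate, not a measurement). For compound 3 the estimate is 6000 nM (expected range 1500 nM to 20000 nM).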

Compound 3, half-maximal inhibitory concentration: 10000 nM
The estimate for compound 3 lay 1.7-fold (0.22 log units) below the measured number, and the stated range covers the measured number.
By their numbers in this assay, from the lowest: compounds 1, 3 and 2 (each within the scatter of the next).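

In this assay, 5-(diethylamino)pentyl in place of 1-methylbutyl gives a 1.5-fold lower number from compound 2 to compound 3 (0.18 log units; within the scatter) and, in place of isopropyl, gives a 1.1-fold higher number from compound 1 to compound 3 (0.06 log units; within the scatter), so both steps lie within the scatter. The earlier pair held only carbon in these chains, whereas compound 3 shows that this oxygen on the shared core can carry a chain ending in a nitrogen-bearing diethylamino group with no change that can be told apart from scatter. No evidence is available to explain this flat result.

On these data alone, whether a shorter chain ending in the same diethylamino group, or a chain ending in a carboxylic acid or a piperidine ring, would move the number beyond the scatter remains open. The compounds shown also leave open how a free hydroxyl at this position would compare.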